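Swapping an acetyl for a silicon group

A few compounds are considered here, and "the series" means these few. Any claim that something is new, unique, unknown or untested is made for them only; others in the source may bear on it.

compound 1 `C=C1CC[C@@H]2[C@](C)(COC(C)=O)[C@H](OC(C)=O)CC[C@@]2(C)[C@@H]1C/C=C1/C(=O)OC[C@H]1OC(C)=O` gives 12.4 uM
compound 2 `C=C1CC[C@@H]2[C@](C)(CO[Si](c3ccccc3)(c3ccccc3)C(C)(C)C)[C@H](OC(C)=O)CC[C@@]2(C)[C@@H]1C/C=C1/C(=O)OC[C@H]1O` gives 10.9 uM

Both numbers come from a functional assay on Lu1 cells (Homo sapiens) for cytotoxicity, read by sulforhodamine B assay (on this read-out lower numbers stand for an effect already at smaller amounts and higher numbers for an effect only at larger amounts of compound), and they lie within the usual scatter of each other, so compound 1 shares its place on this short scale with compound 2 and neither can be ranked. Compound 3 `C=C1CC[C@@H]2[C@](C)(CO[Si](C(C)C)(C(C)C)C(C)C)[C@H](OC(C)=O)CC[C@@]2(C)[C@@H]1C/C=C1/C(=O)OC[C@H]1OC(C)=O` has not been measured yet. It keeps the core of compound 1 and differs in one place a group of 10 heavy atoms (9 carbon, 1 silicon; no ring) in place of a group of 3 heavy atoms (2 carbon, 1 oxygen; no ring), on an oxygen on a saturated carbon on an oxygen on a saturated carbon: the acetyl gives way to a group of 10 heavy atoms (9 carbon, 1 silicon; no ring). Among the measured compounds shown here, no measured pair isolates this swap, so its effect can only be judged indirectly. For the measured compounds named here, compound 2, which also carries silicon, gives 10.9 uM in this assay and that value sits within the scatter of the one for compound 1. No step beyond the scatter is therefore expected, and no direction can be named with confidence. The estimated 1.1-fold lower number from compound 1 to compound 3 (0.05 log units; within the scatter) is expected to stay inside that scatter. Compound 3 is expected at 11 uM (estimated range 5 uM to 24 uM).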

Compound 3, concentration for half-maximal effect: 18.8 uM
For compound 3 the middle estimate is 1.7-fold (0.23 log units) below the measured one; measured number inside the range.
By their numbers in this assay, from the lowest: compounds 2, 1 and 3 (each within the scatter of the next).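

Among the compounds shown here, compound 3 gives the first one-place reading at this position, and replacing the acetyl with the silicon group of 10 heavy atoms (9 carbon, 1 silicon) gives a 1.5-fold higher number from compound 1 to compound 3 (0.18 log units; within the scatter) in this assay. The position on an oxygen on a saturated carbon can therefore carry this much larger group, which has no hydrogen-bond acceptor, without a change that can be told apart from the scatter, so the acetyl and its acceptor are not needed to keep the number in this range. No measurement shown here explains this outcome, and the result says only that the swap left the number within the scatter.

As far as these compounds go, it remains open whether a different kind of group on this oxygen, such as an amine-bearing chain, a carboxylic acid or a longer ester chain, would move the number beyond the scatter in this assay. It is also unknown whether this tolerance extends to other cell lines, since the only read-out here is cytotoxicity on a single one.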